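Replacing the amine substituent on the piperidine ring

A few compounds are considered here, and "the series" means these few. Any claim that something is new, unique, unknown or untested is made for them only; others in the source may bear on it.

Compound 2 `CN(Cc1ccsc1)C1CCN(CCCc2c[nH]c3ccc(-n4cnnc4)cc23)CC1` — 4.2 nM
Compound 1 `c1ccc2c(c1)CCC2NC1CCN(CCCc2c[nH]c3ccc(-n4cnnc4)cc23)CC1` — 25 nM

Two compounds share the core and differ only in the amine on a saturated ring carbon. In an assay on CHO cells for agonist activity at 5-hydroxytryptamine receptor 1D (Homo sapiens), read by GTPgammaS binding (a higher number here means that more compound is needed for the effect, a lower number that less compound is needed), compound 2 gives 4.2 nM, the lowest of the two numbers, and compound 1 gives 25 nM. Going by the values given here, the one measured step, a 6.0-fold lower number from compound 1 to compound 2 (0.77 log units; beyond the scatter), shows that exchanging the (2,3-dihydro-1H-inden-1-yl)amino group for the smaller methyl((thiophen-3-yl)methyl)amino group lowered the number.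

Compound 3 `CC(CO)(NC1CCN(CCCc2c[nH]c3ccc(-n4cnnc4)cc23)CC1)c1ccccc1` carries (1-(hydroxymethyl)-1-phenylethyl)amino in place of methyl((thiophen-3-yl)methyl)amino on a saturated ring carbon. This step bears on the earlier one in reverse: the entering group is larger than the leaving one, as the indanyl group of compound 1 was. The step from compound 2 to compound 3 is therefore expected to raise the number, by roughly a 4.8-fold higher number from compound 2 to compound 3 (0.68 log units; beyond the scatter). Compound 3 is estimated at 20 nM, with a range from 6 nM to 60 nM.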

Compound 3, half-maximal effective concentration: 3.4 nM
Compound 3: middle estimate off by 5.9-fold (0.77 log units), on the high side; the whole stated range lies above it.
By their numbers in this assay, from the lowest: compounds 3 and 2 (each within the scatter of the next); then compound 1.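

In this assay, the (1-(hydroxymethyl)-1-phenylethyl)amino group, with more heavy atoms than the group it replaces, gives a 1.2-fold lower number from compound 2 to compound 3 (0.09 log units; within the scatter), so at this saturated ring carbon the heavy-atom count does not set the number across these compounds. The same amine nitrogen shows a clear difference when only its substituent changes, with a 7.4-fold lower number from compound 1 to compound 3 (0.87 log units; beyond the scatter), so among these compounds a hydrogen on that nitrogen does not tie the number to that of compound 1, and the methyl of compound 2 is not needed for a number in this range. Nothing given here accounts for either step.

The compounds shown leave open what the hydroxymethyl of compound 3 contributes. They also leave open whether a carboxylic acid in its place, or a methyl on the amine nitrogen of compound 3, would keep the number in this range.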